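The compounds below may be only part of what the source reports. "The series", "measured", "known", "first", "only" and "open" are said of these compounds alone.

Compound 1 `COc1cc(N(C)C(=O)c2cccc([N+](=O)[O-])c2)cc(OC)c1OC` is examined in a functional assay on Daoy cells (Homo sapiens) for cytotoxicity, read by MTT assay, with a stated time of 72 h; a higher number here means a weaker inhibitor, a lower number a stronger inhibitor. In that setting compound 1 returns only a limit, >= 125000 nM. Compound 3 `COc1cc(NC(=O)c2cccc([N+](=O)[O-])c2)cc(OC)c1OC`, which carries hydrogen in place of methyl on an amide-type nitrogen, likewise reaches only a limit, >= 125000 nM. The step that the two limits leave unreadable from compound 1 to compound 3 therefore cannot be sized, because of the limit of >= 125000 nM in this assay, at which 2 of the 3 values shown sit. Compound 2 `COc1cc(NC(=O)Nc2cccc(F)c2)cc(OC)c1OC` gives 111000 nM in this assay. Compound 4 `COc1cc(N(C)C(=O)c2cccc(F)c2)cc(OC)c1OC` differs from compound 1 by fluoro in place of nitro on an aromatic carbon. Going by the values given here, no measured step tracks this change alone. Since the value of compound 2 sits at 111000 nM, no shift beyond the scatter is expected for an at least 1.0-fold lower number from compound 1 to compound 4 (0.01 log units; that floor lies within the scatter). Compound 4 is accordingly estimated at 120000 nM, within 50000 nM to 300000 nM, with a real chance that only a limit is reported again.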

Compound 4, half-maximal inhibitory concentration: >= 125000 nM
Compound 4 gave a limit, no number; the forecaster's own chance of this, stated with the estimate: 65%; middle value at least 1.0-fold (0.01 log units) from the limit.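

No step can be read from compound 1 to compound 4, since each gives only a limit: the limit of >= 125000 nM in this assay, at which 3 of the 4 values shown sit. From the compounds shown here alone, whether fluoro and nitro on this aromatic carbon differ at all in this assay remains open.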